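Replacing 3-Fluorophenyl with Thiophen-2-yl

The compounds below may be only part of what the source reports. "The series", "measured", "known", "first", "only" and "open" are said of these compounds alone.

Of the compounds shown here, two sharing one core have been measured in a functional assay on HT-29 cells (Homo sapiens) for inhibition, with a stated time of 72 h; on this read-out lower numbers stand for stronger inhibition and higher numbers for weaker inhibition. There, compound 1 (`COc1ccc(S(=O)(=O)N2CCc3cccc(-c4ccc(F)cc4)c32)cc1`) gives 85.5 nM. Compound 2 (`COc1ccc(S(=O)(=O)N2CCc3cccc(-c4cccc(F)c4)c32)cc1`) gives 119 nM, which places it level with compound 1 on the numbers available, as the two values lie within the scatter of each other.

The next structure is compound 3 (`COc1ccc(S(=O)(=O)N2CCc3cccc(-c4cccs4)c32)cc1`), which carries thiophen-2-yl in place of 3-fluorophenyl on an aromatic carbon. For the measured compounds named here, only one measured step bears on this change, and it does so indirectly. That step, a 1.4-fold higher number from compound 1 to compound 2 (0.14 log units; within the scatter), exchanges 4-fluorophenyl for 3-fluorophenyl at the same place and stays within the scatter. Going by the values given here, it shows that this one exchange left the number in this assay essentially unchanged, but no measured compound carries a five-membered aromatic ring there, so the range must stay wide. A step beyond the scatter is therefore not expected, in either direction. The estimated change is a 1.2-fold higher number from compound 2 to compound 3 (0.07 log units; within the scatter). Compound 3 is expected to give 140 nM, with an estimated range of 50 nM to 400 nM.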

Compound 3, half-maximal inhibitory concentration: 200 nM
Compound 3: middle estimate off by 1.4-fold (0.15 log units), on the low side, within the range that was stated.
By their numbers in this assay, from the lowest: compounds 1, 2 and 3 (each within the scatter of the next, the first and the last beyond it).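

In this assay, for the compounds shown here, thiophen-2-yl is the first five-membered aromatic ring at this position, and putting it in place of 3-fluorophenyl gives a 1.7-fold higher number from compound 2 to compound 3 (0.23 log units; within the scatter), a change that cannot be told apart from repeat variation. Set against 4-fluorophenyl, the same ring gives a 2.3-fold higher number from compound 1 to compound 3 (0.37 log units; beyond the scatter), the first step in the series to pass beyond the scatter, though only modestly; since compound 2 lies within the scatter of both compound 1 and compound 3, this one separated pair is the only firm difference among the three, and the position accepts a smaller ring carrying sulfur and no fluorine with only a modest loss at most. Nothing available accounts for these differences.

What the compounds shown leave open is how the number responds at this position to thiophen-3-yl, furan-2-yl or a pyridine ring, and whether the one modest separation seen here would persist across those rings. Also open, from the compounds shown here alone, is whether an amine or a carboxylic acid on the aromatic ring would produce a larger step than any seen so far.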